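Benzofuran Regained on a Tetradecyl Threonine Amide

This account rests on a few compounds, and the source may have more. Where it says the series, first, only, none or still open, it means among the compounds named here.

Compound 1 `CCCCCCCCCCCCNC(=O)[C@@H](NC(=O)c1cc2ccccc2o1)[C@@H](C)O`: 22900 nM
Compound 2 `CCCCCCCCCCCCCCNC(=O)[C@@H](NC(=O)c1ccccc1)[C@@H](C)O`: 54200 nM
Compound 3 `CCCCCCCCCCCCCCNC(=O)[C@@H](NC(=O)c1ccco1)[C@@H](C)O`: > 400000 nM

In a functional assay on HepG2 cells (Homo sapiens) for cytotoxicity, read by MTT assay, with a stated time of 48 h (on this read-out higher numbers stand for weaker inhibition and lower numbers for stronger inhibition), compound 3 reaches only the limit of the assay, > 400000 nM, and no number is known for it. Compound 2 gives 54200 nM, and compound 1, which carries the 1-benzofuran-2-yl group on a dodecyl chain, gives 22900 nM. Among the compounds with values here, the one measured step that touches the change in question is an at least 7.3-fold higher number from compound 2 to compound 3 (0.86 log units; beyond the scatter), which reads as a loss of potency when the phenyl gives way to the furan; its size is bounded only by the limit of > 400000 nM in this assay, at which 1 of the 3 values shown sits.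

Compound 4 `CCCCCCCCCCCCCCNC(=O)[C@@H](NC(=O)c1cc2ccccc2o1)[C@@H](C)O` differs from compound 3 by 1-benzofuran-2-yl in place of furan-2-yl on a carbonyl carbon, that is, (furan-2-yl)carbonyl to (1-benzofuran-2-yl)carbonyl. The step is expected to run the other way from that of compound 2 to compound 3, bringing compound 4 back into the range of compound 1 and compound 2. Compound 4 is therefore estimated at 30000 nM, between 10000 nM and 150000 nM, which is an expected step of an at least 13-fold lower number from compound 3 to compound 4 (1.12 log units; beyond the scatter).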

Compound 4, half-maximal inhibitory concentration: 23400 nM
For compound 4 the middle estimate is 1.3-fold (0.11 log units) above the measured one, and the stated range covers the measured number.
By their numbers in this assay, from the lowest: compounds 1 and 4 (each within the scatter of the next); then compound 2. At a limit, above all of these: compound 3.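

In this assay, the 1-benzofuran-2-yl group on the carbonyl carbon restores the activity that the furan-2-yl group lacked on the same tetradecyl chain, with an at least 17-fold lower number from compound 3 to compound 4 (1.23 log units; beyond the scatter), and the size of this step is bounded on one side only: the limit of > 400000 nM in this assay, at which 1 of the 4 values shown sits.

The 1-benzofuran-2-yl group also improves on phenyl at this place, with a 2.3-fold lower number from compound 2 to compound 4 (0.36 log units; beyond the scatter). With 1-benzofuran-2-yl in place, the change from a dodecyl to a tetradecyl chain has no readable effect, with a 1.0-fold higher number from compound 1 to compound 4 (0.01 log units; within the scatter).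

The compounds shown leave open whether an amine or a carboxylic acid on the 1-benzofuran-2-yl group would keep this activity. They also leave open how a chain longer than tetradecyl would read in this assay.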